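The compounds below may be only part of what the source reports. "The series", "measured", "known", "first", "only" and "open" are said of these compounds alone.

Three compounds carry numbers in a functional assay on PC-3 cells (Homo sapiens) for cytotoxicity, read by MTT assay, with a stated time of 48 h; a higher number here means a weaker inhibitor, a lower number a stronger inhibitor. Compound 1 `CC1=NN(C(=O)CCc2ccccc2)C(c2cc(Br)ccc2O)C1` gives 16300 nM. Compound 2 `CCC(=O)N1N=C(C)CC1c1cc(Br)cc(Br)c1O` gives 28600 nM. Compound 3 `CCNCC(=O)N1N=C(c2cc3ccccc3oc2=O)CC1c1ccccc1` gives 5580 nM, the lowest of the three; its gaps to compound 1 and to compound 2 both lie beyond the usual scatter of repeated measurements, so compound 3 stands as the strongest inhibitor of the three measured. For the measured compounds named here, compound 3 differs from the other two in several places at once, so no single-point step among measured compounds can be read from these numbers.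

Compound 4 `CC1CC(C)CN(CC(=O)N2N=C(c3cc4ccccc4oc3=O)CC2c2ccccc2)C1` is not yet measured and differs from compound 3 in one place only. 3,5-dimethylpiperidin-1-yl in place of ethylamino on a saturated chain carbon bound to a carbonyl carbon The carbonyl and the rest of the core of compound 3 stay as they are. Going by the values given here, no measured pair shows an exchange of this kind, so the expectation rests only on the position of compound 3 and on the size of the change. The step of a 1.4-fold lower number from compound 3 to compound 4 (0.14 log units; within the scatter) is expected to stay within or close to the scatter, leaning if anything toward a lower number. Compound 4 is therefore estimated at 4000 nM, with a range from 1500 nM to 12000 nM.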

Compound 4, half-maximal inhibitory concentration: "not active" (no number reported)
Nothing numeric was reported for compound 4, and the estimate cannot be compared.
By their numbers in this assay, from the lowest: compound 3; then compounds 1 and 2 (each within the scatter of the next).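

For the compounds shown here, compound 4 is reported in this assay only as "not active", without a number, so no step from compound 3 can be read. Open is how far the exchange of ethylamino for 3,5-dimethylpiperidin-1-yl moves the number, and no measurement shown bears on the reason for this result.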